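Chloro-to-bromo swap on the benzamide of a chalcone-like core

This account rests on a few compounds, and the source may have more. Where it says the series, first, only, none or still open, it means among the compounds named here.

Measured compounds:
compound 1, `O=C(Nc1cccc(/C=C/C(=O)c2nc3ccccc3[nH]2)c1)c1ccccc1`, 2440 nM
compound 2, `O=C(Nc1cccc(/C=C/C(=O)c2nc3ccccc3[nH]2)c1)c1cccc(Cl)c1`, 1120 nM
compound 3, `O=C(Nc1cccc(/C=C/C(=O)c2nc3ccccc3[nH]2)c1)c1ccc(Cl)cc1`, 2270 nM

In a functional assay on HCT-116 cells (Homo sapiens) for antiproliferative activity, read by MTT assay, with a stated time of 48 h (a higher number here means a weaker inhibitor, a lower number a stronger inhibitor), compound 2 gives the lowest number of the three, with compound 3 nearest and compound 1 furthest. Compound 4, `O=C(/C=C/c1cccc(NC(=O)c2ccccc2Br)c1)c1nc2ccccc2[nH]1`, differs from compound 2 by 2-bromophenyl in place of 3-chlorophenyl on a carbonyl carbon. Going by the values given here, the steps that bear on this change are a 2.2-fold lower number from compound 1 to compound 2 (0.34 log units; beyond the scatter) and a 2.0-fold higher number from compound 2 to compound 3 (0.31 log units; beyond the scatter), while a 1.1-fold lower number from compound 1 to compound 3 (0.03 log units; within the scatter); the benefit seen with 3-chlorophenyl does not carry to 4-chlorophenyl, and no measured compound carries a 2-bromophenyl. A modest step toward a higher number is therefore expected, a 1.8-fold higher number from compound 2 to compound 4 (0.25 log units; within the scatter), with wide uncertainty. Compound 4 is estimated at 2000 nM, in the range 800 nM to 5000 nM.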

Compound 4, half-maximal inhibitory concentration: 1680 nM
For compound 4 the middle estimate is 1.2-fold (0.08 log units) above the measured one, and the stated range covers the measured number.
By their numbers in this assay, from the lowest: compounds 2, 4, 3 and 1 (each within the scatter of the next, the first and the last beyond it).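

In this assay, the 2-bromophenyl group on this carbonyl carbon cannot be told apart from any of the three earlier groups: the steps read a 1.5-fold higher number from compound 2 to compound 4 (0.18 log units; within the scatter) and a 1.4-fold lower number from compound 3 to compound 4 (0.13 log units; within the scatter) and a 1.5-fold lower number from compound 1 to compound 4 (0.16 log units; within the scatter) for this change. Unlike the gap between 3-chlorophenyl and 4-chlorophenyl, none of these steps lies beyond the scatter. No evidence on why this is so is at hand.

The step from compound 2 alters both the halogen and its ring position at once, leaving their separate contributions open. On these data alone, how a 2-chlorophenyl, a 3-bromophenyl or an aminophenyl group would read at this carbonyl carbon also remains open.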